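Carbonyl substituent variation on a shared core

The source may report more compounds than this note shows. Statements on the series, on what has been measured and on what is new or still open speak of the compounds shown alone.

Three compounds sharing one core differ only in the group on a carbonyl carbon: compound 1 `CC1=C(C(=O)OC(C)(C)C)C(c2ccsc2)NC(=O)N1`, compound 2 `CC1=C(C(=O)C2CC2)C(c2ccsc2)NC(=O)N1` and compound 3 `CC1=C(C(=O)CC(C)C)C(c2ccsc2)NC(=O)N1`. In an assay on membranes from HeLa cells for displacement of a labelled ligand from adenosine receptor A3 (Homo sapiens), read by scintillation counting, with a stated time of 180 min, tested at 1 uM (a higher number here means more inhibition at the concentration tested (going by the name of the read-out), a lower number less inhibition), compound 1 gives 1%, compound 2 gives 1% and compound 3 gives 14%. Compound 3 thus sits highest of the three: a number 13 percentage points higher from compound 1 to compound 3 (beyond the scatter) and a number 13 percentage points higher from compound 2 to compound 3 (beyond the scatter), whereas no change at the digits printed from compound 1 to compound 2 (within the scatter). Compound 4 `CC1=C(C(N)=O)C(c2ccsc2)NC(=O)N1` carries amino in place of isobutyl on a carbonyl carbon. All three measured steps concern this same carbonyl carbon; tert-butoxy and cyclopropyl sit together at the low end, and only isobutyl lifts the number, modestly. Replacing isobutyl by amino is therefore expected to return compound 4 to that low end, estimated at 3% (range 0% to 12%), a step of a number 11 percentage points lower from compound 3 to compound 4 (beyond the scatter).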

Compound 4, a percentage reported as inhibition, at one concentration (the size of the read-out at that concentration, not a potency): 1%
Compound 4: the middle estimate sits 2 percentage points above what was measured, within the range that was stated.
By their numbers in this assay, from the lowest: compounds 1, 2 and 4 (each within the scatter of the next); then compound 3.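

On this carbonyl carbon, amino in place of isobutyl removes the modest lift in this assay, with a number 13 percentage points lower from compound 3 to compound 4 (beyond the scatter). Amino also stands level with the other two groups, with no change at the digits printed from compound 2 to compound 4 (within the scatter) and no change at the digits printed from compound 1 to compound 4 (within the scatter), so isobutyl remains the only one of the four groups that raises the number. Nothing available explains this difference.

Going by these compounds, whether a longer chain or a benzyl group on this carbonyl carbon would exceed compound 3 stays open. So does whether a substituted amine such as dimethylamino would stay level with compound 4.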